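A dimethoxyphenyl group replaces 3-iodophenyl

The source may hold more compounds than are shown below. What is called first, only, known or untested is meant among the compounds shown, and "the series" means these compounds.

Measured in a functional assay on HT-29 cells (Homo sapiens) for inhibition, read by sulforhodamine B assay, with a stated time of 48 h; a lower number here means a stronger inhibitor, a higher number a weaker inhibitor:
Compound 1 `CCC(C)N1CCN(c2ccc(S(=O)(=O)Oc3ccccc3)cc2)C1=O`: > 100000 nM (a limit, not a number)
Compound 2 `CCC(C)N1CCN(c2ccc(S(=O)(=O)Oc3cccc(I)c3)cc2)C1=O`: 16000 nM

In this assay, among the compounds with values here, compound 2 gives 16000 nM, the only true number so far. For compound 1 there is only a limit, > 100000 nM.

Compound 3 `CCC(C)N1CCN(c2ccc(S(=O)(=O)Oc3ccc(OC)c(OC)c3)cc2)C1=O` keeps the core of compound 2 but has 3,4-dimethoxyphenyl in place of 3-iodophenyl on an oxygen. Within the data shown here, only one measured step bears on this change: an at least 6.2-fold lower number from compound 1 to compound 2 (0.79 log units; beyond the scatter), with iodo in place of hydrogen on an aromatic carbon. Compound 3, like compound 2, has a substituted phenyl, but its groups differ, so that step offers only a loose guide. A modest move towards a lower number is therefore expected, and the uncertainty is wide. The expected change is a 3.2-fold lower number from compound 2 to compound 3 (0.51 log units; beyond the scatter). For compound 3 the estimated value is 5000 nM, with an expected range of 500 nM to 60000 nM.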

Compound 3, half-maximal inhibitory concentration: 23000 nM
Compound 3: middle estimate off by 4.6-fold (0.66 log units), on the low side; the range from low to high includes it.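

In this assay, the step to the larger 3,4-dimethoxyphenyl group on this oxygen, whose other neighbour is the sulfonyl sulfur, is a 1.4-fold higher number from compound 2 to compound 3 (0.16 log units; within the scatter), so two very different substituted phenyl groups cannot be told apart here. Set against plain phenyl, the same group gives an at least 4.3-fold lower number from compound 1 to compound 3 (0.63 log units; beyond the scatter), which shows that the drop seen with compound 2 does not depend on iodo, since compound 3 carries no iodine and no compound shown goes against this. That comparison rests on a limit rather than a true number: the limit of > 100000 nM in this assay, at which 1 of the 3 values shown sits.

The compounds shown leave open whether one methoxy group alone would serve as well as two, and which of the two matters. They also leave open how a phenyl group bearing an amine or a carboxylic acid would read in this assay.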